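The source may report more compounds than this note shows. Statements on the series, on what has been measured and on what is new or still open speak of the compounds shown alone.

Measured in an assay on isolated protein for binding affinity to secreted frizzled-related protein 1 (Homo sapiens), read by fluorescence; a lower number here means a stronger inhibitor, a higher number a weaker inhibitor:
Compound 1, `O=C(CN1CCNCC1)N1CCC(NS(=O)(=O)c2cc(S(=O)(=O)c3ccccc3)ccc2C(F)(F)F)CC1`, gives 140 nM.
Compound 2, `CC(C)C(=O)N1CCC[C@H]1C(=O)N1CCC(NS(=O)(=O)c2cc(S(=O)(=O)c3ccccc3)ccc2C(F)(F)F)CC1`, gives 40 nM.
Compound 3, `CN(C)C(=O)N1CCC[C@H]1C(=O)N1CCC(NS(=O)(=O)c2cc(S(=O)(=O)c3ccccc3)ccc2C(F)(F)F)CC1`, gives 30 nM.

Compound 3 holds the lowest of the three numbers in this assay, but compound 2 sits within the scatter of it (a 1.3-fold lower number from compound 2 to compound 3 (0.12 log units; within the scatter)), so no order between those two can be claimed; compound 1 lies further off (a 4.7-fold lower number from compound 1 to compound 3 (0.67 log units; beyond the scatter)). Compound 4, `CN1CCC[C@H]1C(=O)N1CCC(NS(=O)(=O)c2cc(S(=O)(=O)c3ccccc3)ccc2C(F)(F)F)CC1`, differs from compound 3 by methyl in place of dimethylcarbamoyl on an amine nitrogen in a ring. For the measured compounds named here, no measured step removes a carbonyl at this position, so the bearing of the known steps is indirect. a 3.5-fold lower number from compound 1 to compound 2 (0.54 log units; beyond the scatter) and a 4.7-fold lower number from compound 1 to compound 3 (0.67 log units; beyond the scatter) show that both acylated pyrrolidinyl groups gave modestly lower numbers than the piperazinylmethyl group of compound 1, while a 1.3-fold lower number from compound 2 to compound 3 (0.12 log units; within the scatter) shows that swapping one group on that carbonyl carbon changed little. Compound 4 keeps the pyrrolidinyl ring but drops the carbonyl-bearing group, and a modest rise in its number toward that of compound 1 is expected, a 2.3-fold higher number from compound 3 to compound 4 (0.37 log units; beyond the scatter). Compound 4 is therefore estimated at 70 nM, within 25 nM to 200 nM.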

Compound 4, half-maximal inhibitory concentration: 120 nM
Estimate against measurement, compound 4: 1.7-fold (0.23 log units) below, and the stated range covers the measured number.
By their numbers in this assay, from the lowest: compounds 3 and 2 (each within the scatter of the next); then compounds 4 and 1 (each within the scatter of the next).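

In this assay, replacing the group on the amine nitrogen in the ring with methyl costs affinity, whichever carbonyl-bearing group leaves: dimethylcarbamoyl gives a 4.0-fold higher number from compound 3 to compound 4 (0.60 log units; beyond the scatter), and isopropylcarbonyl gives a 3.0-fold higher number from compound 2 to compound 4 (0.48 log units; beyond the scatter). For the compounds shown here, the earlier compounds showed only that these two carbonyl-bearing groups could stand in for each other; the new steps show that either one goes with a lower number than methyl at this nitrogen. The pyrrolidine ring alone does not account for the advantage of compounds 2 and 3 over compound 1, as the step to 1-methylpyrrolidin-2-yl stays within the scatter, a 1.2-fold lower number from compound 1 to compound 4 (0.07 log units; within the scatter).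

No measurement shown gives a reason for this difference. Going by these compounds, it remains open whether a free ring amine, an acetyl group or a longer acyl chain on this nitrogen would align with compound 4 or with compounds 2 and 3.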